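The compounds below may be only part of what the source reports. "The series", "measured", "known", "first", "only" and "open" are said of these compounds alone.

In an ADME assay on HFF cells (Homo sapiens) for cytotoxicity, read by resazurin assay, with a stated time of 96 h (on this read-out higher numbers stand for lower toxicity in this test and lower numbers for higher toxicity in this test), compound 1 (`CN1CCN(c2ccc3nc(-c4cccc5ccccc45)c(-c4ccncc4)n3n2)CC1`) gives 21300 nM and compound 2 (`CN1CCN(c2ccc3nc(-c4cccc(-c5ccsc5)c4)c(-c4ccncc4)n3n2)CC1`) gives 6300 nM as the lower of the two numbers. Compound 3 (`CN1CCN(c2ccc3nc(-c4ccc5ncsc5c4)c(-c4ccncc4)n3n2)CC1`) has 1,3-benzothiazol-6-yl in place of 3-(thiophen-3-yl)phenyl on an aromatic carbon. For the measured compounds named here, the one measured step bearing on this is a 3.4-fold lower number from compound 1 to compound 2 (0.53 log units; beyond the scatter) and it is modest, with 3-(thiophen-3-yl)phenyl entering in place of naphthalen-1-yl. A step of similar or smaller size towards a higher number is therefore expected in this assay on this single precedent. The expected change is a 2.1-fold higher number from compound 2 to compound 3 (0.31 log units; beyond the scatter) for now. For compound 3 the estimated value is 13000 nM with an expected range of 5500 nM to 32000 nM as its spread.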

Compound 3, half-maximal cytotoxic concentration: 17500 nM
The estimate for compound 3 lay 1.3-fold (0.13 log units) below the measured number; the range from low to high includes it.
By their numbers in this assay, from the lowest: compound 2; then compounds 3 and 1 (each within the scatter of the next).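

At this position on the shared core, this assay shows that the number can rise again: there is a 2.8-fold higher number from compound 2 to compound 3 (0.44 log units; beyond the scatter) with 1,3-benzothiazol-6-yl entering in place of 3-(thiophen-3-yl)phenyl. Against naphthalen-1-yl the same group gives a 1.2-fold lower number from compound 1 to compound 3 (0.09 log units; within the scatter) and so does not separate from it, leaving 3-(thiophen-3-yl)phenyl as the only one of the three groups set apart beyond the scatter from both others.

On these data alone, whether a non-aromatic group here, such as a morpholine ring or a carboxylic acid on a short chain, would hold the number in this range stays open. Nothing available accounts for the gap between these groups.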